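The source may hold more compounds than are shown below. What is called first, only, known or untested is meant among the compounds shown, and "the series" means these compounds.

For the measured compounds named here, compound 2 `COCCNC(=O)C[C@H](NC(=O)c1ccc(C#Cc2ccccc2)cc1)C(=O)NO` stands highest of the two numbers so far in a physicochemical assay for solubility (on this read-out lower numbers stand for lower solubility and higher numbers for higher solubility), where compound 2 gives 78000 nM. Going by the values given here, compound 1 `C#CCNC(=O)C[C@H](NC(=O)c1ccc(C#Cc2ccccc2)cc1)C(=O)NO` gives 8000 nM in this assay, and the single measured step, a 9.8-fold higher number from compound 1 to compound 2 (0.99 log units; beyond the scatter), is all there is to go on. Compound 3 `O=C(C[C@H](NC(=O)c1ccc(C#Cc2ccccc2)cc1)C(=O)NO)NCCCO` differs from compound 2 by hydroxymethyl in place of methoxy on a saturated chain carbon, two bonds along the chain from an amide-type nitrogen. Among the compounds with values here, no measured step covers this change, so in this assay only a small step is expected, upward if anything, and well inside a wide range. Compound 3 is estimated at 100000 nM, between 30000 nM and 300000 nM. This means an expected step of a 1.3-fold higher number from compound 2 to compound 3 (0.11 log units; within the scatter).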

Compound 3, solubility: 82000 nM
Estimate against measurement, compound 3: 1.2-fold (0.09 log units) above; low and high end bracket the measured number.
By their numbers in this assay, from the lowest: compound 1; then compounds 2 and 3 (each within the scatter of the next).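

In this assay, hydroxymethyl in place of methoxy on a saturated chain carbon, two bonds along the chain from an amide-type nitrogen, gives a 1.1-fold higher number from compound 2 to compound 3 (0.02 log units; within the scatter), so this exchange of a methoxy end for a hydroxyl-bearing one leaves the read-out within the scatter. 2-Hydroxyethyl in place of ethynyl gives a 10-fold higher number from compound 1 to compound 3 (1.01 log units; beyond the scatter), placing compound 3 with compound 2 and beyond the scatter from compound 1. No supporting data bear on this result. On these data alone, whether an amine, a carboxylic acid or a longer chain at this place would hold this level remains open.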